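This account rests on a few compounds, and the source may have more. Where it says the series, first, only, none or still open, it means among the compounds named here.

Measured compounds:
- compound 1, `Cc1cc(C)n(-c2nc(C(F)(F)F)cc(=O)[nH]2)n1`: in a physicochemical assay for solubility, at pH 7.4 (a lower number here means a less soluble compound, a higher number a more soluble compound), compound 1 gives 200000 nM
- compound 2, `CCNc1cc(C)nn1-c1nc(C(F)(F)F)cc(=O)[nH]1`: compound 2 gives 85000 nM
- compound 3, `Cc1cc(NCCN(C)C)n(-c2nc(C(F)(F)F)cc(=O)[nH]2)n1`: compound 3 gives 200000 nM

The three measured compounds share a core and differ at one aromatic carbon. Compound 1 and compound 2 differ by methyl in place of ethylamino on an aromatic carbon. From compound 1 to compound 2 the solubility moved by a 2.4-fold lower number from compound 1 to compound 2 (0.37 log units; beyond the scatter), while from compound 1 to compound 3 it showed no change at the digits printed from compound 1 to compound 3 (within the scatter). Compound 1 and compound 3 therefore stand together at the highest value among the three, and the two are within the scatter of each other.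

The unmeasured compound 4, `Cc1cc(CN(C)C)nn1-c1nc(C(F)(F)F)cc(=O)[nH]1`, is derived from compound 1 by dimethylamino in place of hydrogen on a saturated chain carbon bound to an aromatic carbon. The same kind of change is already on record between two measured compounds: compound 3 is derived from compound 2 by dimethylamino in place of hydrogen on a saturated chain carbon, two bonds along the chain from a nitrogen on an aromatic ring, and that step gave a 2.4-fold higher number from compound 2 to compound 3 (0.37 log units; beyond the scatter). The surroundings of the change are not identical, though: in the measured pair the dimethylamino sits on a saturated chain carbon two bonds along the chain from a nitrogen on an aromatic ring, whereas in compound 4 it sits on a saturated chain carbon bound to an aromatic carbon. The cores of the two pairs also differ, as described by methyl in place of ethylamino on an aromatic carbon.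

Resting on the measured step from compound 2 to compound 3, compound 4 is expected to move from compound 1 by about a 1.4-fold higher number from compound 1 to compound 4 (0.15 log units; within the scatter). Since compound 1 already starts at 200000 nM, the expected value for compound 4 in this assay is estimated at 280000 nM, with a range from 120000 nM to 600000 nM.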

Compound 4, solubility: 200000 nM
For compound 4 the middle estimate is 1.4-fold (0.15 log units) above the measured one, within the range that was stated.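

In this assay, dimethylamino in place of hydrogen gave a 2.4-fold higher number from compound 2 to compound 3 (0.37 log units; beyond the scatter), a step beyond the scatter, whereas the same kind of change on a saturated chain carbon bound to an aromatic carbon gave no change at the digits printed from compound 1 to compound 4 (within the scatter), within the scatter, so the step seen on one core did not reappear at a size beyond the scatter on the other. This does not show that the change has no effect on the core of compound 1 in general, nor that the core rather than the place decides the outcome: the two steps differ in both, with dimethylamino two bonds along the chain from a nitrogen on an aromatic ring in compound 3 and on a carbon bound to an aromatic carbon in compound 4, and each rests on a single pair of compounds. Nothing among the data given offers an explanation for the difference between the two steps.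

The compounds shown leave open whether dimethylamino on a longer chain on the core of compound 1 would give a step like the one to compound 3 or the one to compound 4. They also leave open how another group in that place, such as a morpholine or a carboxylic acid, would read in this assay.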